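The compounds below may be only part of what the source reports. "The series", "measured", "known", "first", "only" and "open" are said of these compounds alone.

Compound 3 (`CCn1cc(-c2cc(C(O)(C(F)(F)F)C(F)(F)F)cnc2N2CCN(S(=O)(=O)c3ccc(N)nc3)CC2)cn1`) stands at 194 mL.min-1.g-1 in an ADME assay (liver) for metabolic stability, with Liver microsome (Rattus norvegicus) as the target, using microsomes and NADPH, with a stated time of 30 min, tested at 1 uM (on this read-out lower numbers stand for slow clearance and higher numbers for fast clearance), and holds the highest of the three numbers, ahead of compound 2 (`Cn1cc(-c2cc(C(O)(C(F)(F)F)C(F)(F)F)cnc2N2CCN(S(=O)(=O)c3ccc(N)nc3)CC2)cn1`) at 44 mL.min-1.g-1 and compound 1 (`Nc1ccc(S(=O)(=O)N2CCN(c3ncc(C(O)(C(F)(F)F)C(F)(F)F)cc3C3CC3)CC2)cn1`) at 27 mL.min-1.g-1 on the same read-out. Compound 4 (`Cc1csc(-c2cc(C(O)(C(F)(F)F)C(F)(F)F)cnc2N2CCN(S(=O)(=O)c3ccc(N)nc3)CC2)c1`) has not yet been measured. It carries 4-methylthiophen-2-yl in place of 1-ethyl-1H-pyrazol-4-yl on an aromatic carbon. For the measured compounds named here, three measured steps bear on this change. The step of a 1.6-fold higher number from compound 1 to compound 2 (0.21 log units; within the scatter) stays within the scatter, while a 7.2-fold higher number from compound 1 to compound 3 (0.86 log units; beyond the scatter) and a 4.4-fold higher number from compound 2 to compound 3 (0.64 log units; beyond the scatter) are modest and lie beyond it. Going by the values given here, none of them brings in 4-methylthiophen-2-yl, so the data hold no direct precedent. Since compound 3 at 194 mL.min-1.g-1 sits at the top of the measured range, a modest downward step in this assay is expected, estimated as a 2.2-fold lower number from compound 3 to compound 4 (0.33 log units; beyond the scatter) with wide uncertainty. Compound 4 is estimated at 90 mL.min-1.g-1 with an expected range from 30 mL.min-1.g-1 to 250 mL.min-1.g-1 on this read-out.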

Compound 4, intrinsic clearance in microsomes: 399 mL.min-1.g-1
The estimate for compound 4 lay 4.4-fold (0.65 log units) below the measured number; measured number outside the range, above it.
By their numbers in this assay, from the lowest: compounds 1 and 2 (each within the scatter of the next); then compound 3; then compound 4.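

In this assay, 4-methylthiophen-2-yl on this aromatic carbon goes beyond every group seen there so far, with a 2.1-fold higher number from compound 3 to compound 4 (0.31 log units; beyond the scatter) and a 9.1-fold higher number from compound 2 to compound 4 (0.96 log units; beyond the scatter) and a 15-fold higher number from compound 1 to compound 4 (1.17 log units; beyond the scatter). This shows that compound 3 did not mark the top of the range at this position, and that a five-membered aromatic ring with a single hetero atom, sulfur, can stand higher than either pyrazole. The data offer no measurement that accounts for this rise.

Going by these compounds, it remains open whether the rise belongs to the thiophene ring or to its methyl group, which plain thiophen-2-yl would separate. On these data alone, it is equally open whether an amine or a carboxylic acid on the five-membered ring would bring the number back towards compound 1 at 27 mL.min-1.g-1.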